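A few compounds are considered here, and "the series" means these few. Any claim that something is new, unique, unknown or untested is made for them only; others in the source may bear on it.

Compound 1 `Cn1c(=O)c(S(=O)(=O)Cc2ccc(F)cc2F)cc2cnc(Nc3ccc4[nH]ccc4c3)nc21` belongs to a small set of three compounds sharing one core and tested in a functional assay on DU-145 cells (Homo sapiens) for inhibition, read by trypan blue exclusion, with a stated time of 72 h; on this read-out higher numbers stand for weaker inhibition and lower numbers for stronger inhibition. In this assay compound 1 gives 1000 nM, the second highest of the three numbers. Compound 3 `CCn1c(=O)c(S(=O)(=O)c2ccc(F)cc2F)cc2cnc(Nc3ccc4[nH]ccc4c3)nc21`, the nearest to it, gives 750 nM, a value that sits within the scatter of compound 1, so no order between the two can be read. Compound 2 `Cn1c(=O)c(S(=O)(=O)c2ccc(F)cc2F)cc2cnc(Nc3ccc4[nH]ncc4c3)nc21` gives 30000 nM, a number far beyond the scatter from compound 1; it differs from compound 1 in more than one place, so its gap cannot be tied to a single change.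

Compound 4 `Cn1c(=O)c(S(=O)(=O)c2ccc(F)cc2[N+](=O)[O-])cc2cnc(Nc3ccc4[nH]ccc4c3)nc21` is not yet measured. It differs from compound 1 in one place: 4-fluoro-2-nitrophenyl in place of 2,4-difluorobenzyl on a sulfonyl sulfur. Among the compounds with values here, compound 3 shows that a phenyl directly on the sulfonyl sulfur is compatible with a number like 750 nM, but no measured pair isolates the nitro group. The step of a 1.5-fold higher number from compound 1 to compound 4 (0.18 log units; within the scatter) is therefore expected to be small, towards a somewhat weaker inhibition, and possibly within the scatter. Compound 4 is estimated to give 1500 nM, with a range from 300 nM to 8000 nM.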

Compound 4, half-maximal inhibitory concentration: 1500 nM
Compound 4: the middle estimate sits on the measured number at the digits printed, and the stated range covers the measured number.
By their numbers in this assay, from the lowest: compounds 3, 1 and 4 (each within the scatter of the next); then compound 2.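

Within the data shown here, the step of a 1.5-fold higher number from compound 1 to compound 4 (0.18 log units; within the scatter) is the first direct reading at this position on the sulfonyl sulfur, and in this assay it lies within the scatter. Replacing 2,4-difluorobenzyl with 4-fluoro-2-nitrophenyl, which takes the count of hydrogen-bond acceptors in this group from 0 to 2, therefore produces no readable change in the number. No measurement shown here explains this outcome.

This single step swaps benzyl for phenyl and changes the ring substituents together, so the compounds shown cannot assign any share of it to the nitro group or to the one-carbon link to the ring. Going by these compounds, it also remains open whether a carboxylic acid or an amine on this ring, or a longer chain between the sulfonyl sulfur and the ring, would shift the number beyond the scatter.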